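A few compounds are considered here, and "the series" means these few. Any claim that something is new, unique, unknown or untested is made for them only; others in the source may bear on it.

Compound 1 `Cc1cccc(CNc2ncnc3c2ncn3[C@@H]2O[C@H](CO)[C@@H](O)[C@H]2O)c1` is a nucleoside-like molecule carrying a 3-methylbenzyl group. In a functional assay on MCF cells (Homo sapiens) for antiproliferative activity, with a stated time of 72 h (a lower number here means a stronger inhibitor, a higher number a weaker inhibitor), compound 1 gives only a limit, > 166000 nM. Compound 2 `OC[C@H]1O[C@@H](n2cnc3c(NCc4ccc(F)cc4Cl)ncnc32)[C@H](O)[C@@H]1O` also gives only a limit in this assay, > 166000 nM. For the measured compounds named here, the one measured step, a step that the two limits leave unreadable from compound 1 to compound 2, therefore cannot be sized, and the limit of > 166000 nM in this assay, at which 2 of the 2 values shown sit, shows that neither compound reaches a readable number. Compound 3 `OC[C@H]1O[C@@H](n2cnc3c(NCc4cc(O)cc(O)c4)ncnc32)[C@H](O)[C@@H]1O` differs from compound 1 by 3,5-dihydroxyphenyl in place of 3-methylphenyl on a saturated chain carbon bound to a nitrogen on an aromatic ring. With no readable step to lean on, compound 3 is expected to sit near the same limit, an estimated step that the limit leaves unreadable from compound 1 to compound 3, giving an expected 200000 nM with a range from 80000 nM to 600000 nM.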

Compound 3, half-maximal inhibitory concentration: > 166000 nM
Compound 3: a limit, no number; the forecaster's own chance of this, stated with the estimate: 80%; the middle value is on the limit's open side.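

Compound 1, compound 2 and compound 3 all stop at a limit, so no step among them can be read: the limit of > 166000 nM in this assay, at which 3 of the 3 values shown sit.

What the compounds shown leave open is how strongly any of them acts, since none reaches a readable number in this assay.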